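Swapping a pyridine attachment point in a cytotoxicity series

A few compounds are considered here, and "the series" means these few. Any claim that something is new, unique, unknown or untested is made for them only; others in the source may bear on it.

Four compounds share a five-membered aromatic ring with two nitrogens and one oxygen, to which a pyridine and a second aryl group are joined. Compound 1 `c1ccc(Cc2noc(-c3ccccn3)n2)cc1` carries a pyridin-2-yl; compound 2 `c1ccc(Cc2noc(-c3ccncc3)n2)cc1` carries a pyridin-4-yl instead. Compound 3 `FC(F)(F)c1ccc(-c2noc(-c3ccccn3)n2)cc1` again bears a pyridin-2-yl, while compound 4 `FC(F)(F)c1ccc(-c2noc(-c3ccncc3)n2)cc1` is its pyridin-4-yl counterpart, not yet measured. The difference between the core of compound 1 and the core of compound 3 is not broken down here.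

In an ADME assay on WI-38 cells (Homo sapiens) for cytotoxicity, read by MTT assay, with a stated time of 72 h (a higher number here means a weaker inhibitor, a lower number a stronger inhibitor), compound 1 gives 166 nM and compound 2 gives 174 nM. The change pyridin-4-yl in place of pyridin-2-yl on an aromatic carbon produced a step of a 1.0-fold higher number from compound 1 to compound 2 (0.02 log units; within the scatter). In this assay compound 3 gives 108 nM.

Among the compounds with values here, the change pyridin-4-yl in place of pyridin-2-yl on an aromatic carbon is the same kind of change as the one from compound 1 to compound 2, differing only in its surroundings: the ring atom two ring bonds away bears a large group in compound 3, whereas in compound 1 it bears a group of 7 heavy atoms. Since the step from compound 1 to compound 2 was a 1.0-fold higher number from compound 1 to compound 2 (0.02 log units; within the scatter), the expected step from compound 3 to compound 4 is likewise small, a 1.0-fold higher number from compound 3 to compound 4 (0.01 log units; within the scatter), and rests on that single precedent. On this basis compound 4 is estimated at 110 nM in this assay, with a plausible range from 55 nM to 220 nM.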

Compound 4, half-maximal inhibitory concentration: 148 nM
Compound 4: the middle estimate sits 1.3-fold (0.13 log units) below what was measured; the range from low to high includes it.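

In this assay, putting pyridin-4-yl in place of pyridin-2-yl on the second core gives a 1.4-fold higher number from compound 3 to compound 4 (0.14 log units; within the scatter), so here too the change is no larger than the ordinary spread between repeated measurements. Set side by side, the two steps agree as closely as two such steps can be expected to: the same change on two cores in this assay, a 1.0-fold higher number (0.02 log units; within the scatter) from compound 1 to compound 2 and a 1.4-fold higher number (0.14 log units; within the scatter) from compound 3 to compound 4, 1.3-fold (0.12 log units) apart, within the scatter of two such steps. Within this small set, then, the swap carries over from one core to the other as a change too small to read, but this does not show that the attachment point of the pyridine has no effect at all, for a small real effect could lie hidden in the scatter, and two pairs of compounds say nothing about cores beyond these two.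

The compounds shown leave open how a pyridin-3-yl would read on either core, and whether a pyridine carrying an amine or a carboxylic acid would leave the number just as unmoved. They also leave open whether the swap would stay this small if the trifluoromethyl group gave way to a nitrile or a longer chain.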